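Methyl versus hydrogen beside the amide in a stilbene series

The source may report more compounds than this note shows. Statements on the series, on what has been measured and on what is new or still open speak of the compounds shown alone.

Measured so far:
- compound 1 `COc1ccc(/C=C\c2cc(OC)c(OC)c(OC)c2)cc1NC(=O)CN`: 37.7 nM
- compound 2 `COc1ccc(/C=C\c2cc(OC)c(OC)c(OC)c2)cc1NC(=O)[C@H](C)NC(=O)[C@H](CCCNC(=N)N)NC(=O)[C@H](CCCNC(=N)N)NC(=O)c1ccccc1`: 65.7 nM
- compound 3 `COc1ccc(/C=C\c2cc(OC)c(OC)c(OC)c2)cc1NC(=O)CNC(=O)[C@H](CCCNC(=N)N)NC(=O)[C@H](CCCNC(=N)N)NC(=O)c1ccccc1`: 7.2 nM

All three share the same stilbene core and were tested in an ADME assay on HeLa cells (Homo sapiens) for cytotoxicity, with a stated time of 72 h; on this read-out lower numbers stand for higher toxicity in this test and higher numbers for lower toxicity in this test. In this assay compound 3 gives 7.2 nM, compound 2 gives 65.7 nM, and compound 1 gives 37.7 nM. Compound 1 and compound 2 sit within the scatter of each other; compound 3 stands apart from both.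

Among the measured compounds shown here, the one counted step is a 9.1-fold higher number from compound 3 to compound 2 (0.96 log units; beyond the scatter), brought about by methyl in place of hydrogen on a saturated chain carbon bound to an amide-type nitrogen and a carbonyl carbon. How the core of compound 1 differs from that of compound 3 is not broken down here.

Compound 4 `COc1ccc(/C=C\c2cc(OC)c(OC)c(OC)c2)cc1NC(=O)[C@H](C)N` is still to be measured in this assay. It differs from compound 1 by methyl in place of hydrogen on a saturated chain carbon bound to an amine nitrogen and a carbonyl carbon. The place is not the same word for word as in the step from compound 3 to compound 2: there the chain carbon is bound to an amide-type nitrogen, here to an amine nitrogen. So this is the same kind of change, not the same change.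

Going from compound 1 to compound 4 a step of a 4.0-fold higher number from compound 1 to compound 4 (0.60 log units; beyond the scatter) is expected, resting on the single precedent a 9.1-fold higher number from compound 3 to compound 2 (0.96 log units; beyond the scatter). That the amine setting in compound 1 is not the amide setting in compound 3 tempers this expectation. The expected value for compound 4 in this assay is 150 nM, with a range from 40 nM to 600 nM.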

Compound 4, half-maximal cytotoxic concentration: 6.69 nM
Estimate against measurement, compound 4: 22-fold (1.35 log units) above, and the stated range ends above it.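

In this assay, methyl in place of hydrogen on a saturated chain carbon bound to an amine nitrogen and a carbonyl carbon gives a 5.6-fold lower number from compound 1 to compound 4 (0.75 log units; beyond the scatter), so the direction of the step does not carry from one core to the other in this series: the same change on two cores in this assay, a 9.1-fold higher number (0.96 log units; beyond the scatter) from compound 3 to compound 2 and a 5.6-fold lower number (0.75 log units; beyond the scatter) from compound 1 to compound 4, 51-fold (1.71 log units) apart, beyond the scatter of two such steps

The earlier step, a 9.1-fold higher number from compound 3 to compound 2 (0.96 log units; beyond the scatter), has the chain carbon bound to an amide-type nitrogen, so a methyl effect read on one core is no safe guide to the other within this pair of steps. Among the compounds shown here, with only one pair on each core, the result does not show whether the amine or amide-type nitrogen, the rest of the chain or some other difference between the cores sets the direction, and it gives no general rule for the series.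

Still open, on these data alone, is whether an acetyl group on the amine nitrogen of compound 4 and of compound 1 would bring the step back towards the direction seen with the amide-type nitrogen. Also open, as far as these compounds go, is how a longer chain, such as ethyl or isopropyl in place of methyl, would behave on each core.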